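This account rests on a few compounds, and the source may have more. Where it says the series, first, only, none or still open, it means among the compounds named here.

Compound 1 `O=C(NC1CCCCC1)Oc1cccc(C2=NCCO2)c1` gives 1.2 nM in an assay (strain Wistar) for inhibition of Fatty-acid amide hydrolase 1 (Rattus norvegicus), read by scintillation counting; a higher number here means a weaker inhibitor, a lower number a stronger inhibitor. Compound 2 `O=C(NC1CCCCC1)Oc1cccc(C2=N[C@H](Cc3ccccc3)CO2)c1` gives 590 nM in this assay, and compound 3 `COC(=O)[C@H]1COC(c2cccc(OC(=O)NC3CCCCC3)c2)=N1` gives 90 nM in this assay. Of these three numbers compound 3 holds the second highest, set apart from both neighbours: it lies beyond the scatter from compound 2 and further still from compound 1. The two steps measured so far both start from compound 1 and both add a group to the saturated ring carbon: a 490-fold higher number from compound 1 to compound 2 (2.69 log units; beyond the scatter) and a 75-fold higher number from compound 1 to compound 3 (1.88 log units; beyond the scatter). Each is large and each raises the number.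

Compound 4 `COC(=O)[C@@H]1COC(c2cccc(OC(=O)NC3CCCCC3)c2)=N1` is the counterpart of compound 3 in which (the two compounds have the same atoms and bonds and differ only in configuration as drawn: 1 of 1 stereo elements differ; a stereocentre at a saturated ring carbon is drawn R in compound 3 and S in compound 4). Going by the values given here, no measured step bears directly on this change: neither of the two steps turns one configuration into the other at that carbon, and no pair among the measured compounds shares atoms and bonds while differing only in configuration. Among the compounds with values here, the steps from compound 1 show only that a group on this carbon costs a great deal, not which configuration costs more. The expectation for compound 4 is therefore a number close to that of compound 3, with a broad range, a step of a 1.3-fold lower number from compound 3 to compound 4 (0.11 log units; within the scatter). Compound 4 is estimated at 70 nM, between 10 nM and 500 nM.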

Compound 4, half-maximal inhibitory concentration: 9.4 nM
Compound 4: the middle estimate sits 7.4-fold (0.87 log units) above what was measured; measured number below the stated range.
By their numbers in this assay, from the lowest: compound 1; then compound 4; then compound 3; then compound 2.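

At this saturated ring carbon the drawn configuration counts in its own right in this assay, with a 9.6-fold lower number from compound 3 to compound 4 (0.98 log units; beyond the scatter), and this gap belongs to the stereocentre alone because nothing else separates the two structures: the fact that compounds 3 and 4 differ only in the configuration as drawn

The price of placing methoxycarbonyl on this carbon therefore depends on configuration: with the stereocentre drawn S it is a 7.8-fold higher number from compound 1 to compound 4 (0.89 log units; beyond the scatter), a modest step, whereas the step to the R form was large. Set against benzyl, methoxycarbonyl gives a 63-fold lower number from compound 2 to compound 4 (1.80 log units; beyond the scatter), although this step alone cannot separate the contribution of the group from any contribution of the arrangement at this carbon.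

It remains open whether benzyl would show a similar gap between its two configurations, since only one configuration of that group appears among the compounds shown. Also open, on these data alone, is whether a carboxylic acid or a hydroxymethyl group on this carbon would respond to configuration in the same way, and whether any group here, in either configuration, could match compound 1 at 1.2 nM.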